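A few compounds are considered here, and "the series" means these few. Any claim that something is new, unique, unknown or untested is made for them only; others in the source may bear on it.

Two compounds of this series have a number in a functional assay on ileum for antagonist activity at histamine H1 receptor (Cavia porcellus), tested at 0.5 mg/mL; a higher number here means that more compound is needed for the effect, a lower number that less compound is needed. Compound 1 `CCN(CC)CC(O)COc1ccc2oc(=O)cc(C)c2c1` carries a diethylamino group on the side chain; in this assay compound 1 gives 0.006 ug/mL. Compound 2 `CCCNCC(O)COc1ccc2c(-c3ccccc3)cc(=O)oc2c1` carries a propylamino group in the same part of the molecule and a phenyl group on the core; in this assay compound 2 gives 0.0063 ug/mL. The two numbers lie within the scatter of each other, so no order between compound 1 and compound 2 can be read from them.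

Compound 3 `O=c1cc(-c2ccccc2)c2ccc(OCC(O)CN3CCNCC3)cc2o1` is not yet measured. It differs from compound 2 in one place: piperazin-1-yl in place of propylamino on a saturated chain carbon, two bonds along the chain from an oxygen on a saturated carbon. Among the measured compounds shown here, no step between measured compounds bears on this exchange; the only guide is that compound 1 and compound 2, with different amines on that chain carbon, give numbers within the scatter. The step from compound 2 to compound 3 is therefore expected to be small, a 1.3-fold higher number from compound 2 to compound 3 (0.10 log units; within the scatter), with no direction beyond the scatter. Compound 3 is estimated at 0.008 ug/mL, within 0.003 ug/mL to 0.025 ug/mL.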

Compound 3, half-maximal effective concentration: 0.0063 ug/mL
Compound 3: the middle estimate sits 1.3-fold (0.10 log units) above what was measured, and the stated range covers the measured number.
By their numbers in this assay, from the lowest: compounds 1, 2 and 3 (each within the scatter of the next).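

In this assay, among the compounds shown here, the exchange of propylamino for piperazin-1-yl on a saturated chain carbon, two bonds along the chain from an oxygen on a saturated carbon, gives no change at the digits printed from compound 2 to compound 3 (within the scatter) and so provides the first one-place reading at this position. With the rest of the molecule held constant, the open chain and the six-membered non-aromatic ring, which has more heavy atoms and one more hydrogen-bond acceptor, give numbers within the scatter. No supporting data bear on why this exchange leaves the number within the scatter.

Going by these compounds, it remains open whether a morpholin-4-yl group, a 4-methylpiperazin-1-yl group or a longer chain such as hexylamino on this chain carbon would also stay within the scatter. On these data alone, the contribution of the phenyl group on the core also remains open, as compound 1 and compound 2 differ in more than one place.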